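Two methyl groups in place of a sulfamoyl group

The source may report more compounds than this note shows. Statements on the series, on what has been measured and on what is new or still open speak of the compounds shown alone.

Compound 1, `Cc1cccc(-n2nncc2CN2C(=O)C3(C(C#N)=C(N)Oc4c3c3nc5ccccc5nc3c3ccccc43)c3ccccc32)c1` — > 50000 nM
Compound 2, `N#CC1=C(N)Oc2c(c3nc4ccccc4nc3c3ccccc23)C12C(=O)N(Cc1cnnn1-c1cccc(Cl)c1)c1ccccc12` — 35200 nM
Compound 3, `N#CC1=C(N)Oc2c(c3nc4ccccc4nc3c3ccccc23)C12C(=O)N(Cc1cnnn1-c1ccc(S(N)(=O)=O)cc1)c1ccccc12` — > 50000 nM

The three measured compounds share one core and differ only in the aryl group on an aromatic nitrogen. In an ADME assay on L02 cells (Homo sapiens) for antiproliferative activity, read by MTT assay, with a stated time of 48 h (a lower number here means a stronger inhibitor, a higher number a weaker inhibitor), compound 1 reaches only the limit > 50000 nM. Compound 2 gives a number, 35200 nM. Compound 3 again gives only the limit > 50000 nM; that limit is all that is known of where it stands. Two of the three values sit at the limit of > 50000 nM in this assay, at which 2 of the 3 values shown sit.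

Compound 4, `Cc1ccc(C)c(-n2nncc2CN2C(=O)C3(C(C#N)=C(N)Oc4c3c3nc5ccccc5nc3c3ccccc43)c3ccccc32)c1`, has not yet been measured in this assay. It differs from compound 3 in one place: 2,5-dimethylphenyl in place of 4-sulfamoylphenyl on an aromatic nitrogen. Of the measured steps, an at least 1.4-fold higher number from compound 2 to compound 3 (0.15 log units; that floor lies within the scatter) bears most directly on this exchange, since it runs the other way over the same position. The step that the two limits leave unreadable from compound 1 to compound 3 cannot be read, and an at least 1.4-fold lower number from compound 1 to compound 2 (0.15 log units; that floor lies within the scatter). For the measured compounds named here, compound 1, the only methylphenyl member, sits at the limit, and compound 4 carries a 2,5-dimethylphenyl group, so no step beyond the scatter toward a lower number is expected. The step that the limit leaves unreadable from compound 3 to compound 4 is expected to stay within the scatter, with a limit the more likely report. Compound 4 is therefore estimated at about 55000 nM, with a range from 30000 nM to 110000 nM.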

Compound 4, half-maximal inhibitory concentration: > 50000 nM
Compound 4 gave a limit, no number (the forecaster's own chance of this, stated with the estimate: 70%); the middle value is on the limit's open side.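

With compound 4, the limit now holds for a 2,5-dimethylphenyl group on the aromatic nitrogen as well as for the methylphenyl and 4-sulfamoylphenyl groups, so in this assay the run of limits spans three different aryl groups at this position: the limit of > 50000 nM in this assay, at which 3 of the 4 values shown sit.

For the compounds shown here, the only readable step is an at least 1.4-fold higher number from compound 2 to compound 4 (0.15 log units; that floor lies within the scatter); the steps from compound 3 and from compound 1 to compound 4 cannot be read. Going by these compounds alone, the extra methyl on the phenyl ring of compound 1 thus brings no number into view, and compound 2, with its 3-chlorophenyl group, remains the one member that goes against the run of limits.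

The compounds shown leave open where compound 1, compound 3 and compound 4 stand beyond the limit, and whether any group at this position separates from compound 2 by more than the scatter. They also leave open whether a phenyl ring carrying a methoxy group, an amine or a carboxylic acid would give a number rather than a limit in this assay.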